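Sulfur-linked series against growth of a prostate line: working notes

The source may hold more compounds than are shown below. What is called first, only, known or untested is meant among the compounds shown, and "the series" means these compounds.

Measured so far:
compound 1 `Cc1ccc(CS(=O)(=O)/C(=C/c2ccccc2OCc2ccccc2)C(=O)c2ccc(Cl)cc2)cc1`: 1000 nM
compound 2 `O=C(/C(=C\c1ccccc1OCc1ccccc1)S(=O)(=O)c1ccc(F)cc1)c1ccc(Cl)cc1`: 1000 nM
compound 3 `Cc1ccc(CS/C(=C/c2ccc(C)s2)C(=O)c2ccc(Cl)cc2)cc1`: 50000 nM

Three compounds have been run in a functional assay on DU-145 cells (Homo sapiens) for inhibition, read by trypan blue exclusion, with a stated time of 96 h; a lower number here means a stronger inhibitor of growth, a higher number a weaker inhibitor of growth. Compound 1 gives 1000 nM and compound 2 gives 1000 nM. The two differ by 4-fluorophenyl in place of 4-methylbenzyl on a sulfonyl sulfur and the step of no change at the digits printed from compound 1 to compound 2 (within the scatter). Compound 3 stands apart, giving 50000 nM, the highest number of the three; its differences from compound 1 cover more than one place, so the difference between the two cores is not broken down here.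

Compound 4 `Cc1ccc(/C=C(/Sc2ccc(F)cc2)C(=O)c2ccc(Cl)cc2)s1` is not yet measured. It differs from compound 3 by 4-fluorophenyl in place of 4-methylbenzyl on a sulfur. This is the same kind of change as that from compound 1 to compound 2, not the same: there the place is a sulfonyl sulfur whose other neighbours are a double-bonded chain carbon, here a sulfur whose other neighbours are a double-bonded chain carbon. With only one earlier case, a step of similar size is expected, a 1.3-fold lower number from compound 3 to compound 4 (0.10 log units; within the scatter), resting on no change at the digits printed from compound 1 to compound 2 (within the scatter). Compound 4 is therefore estimated at 40000 nM, most likely between 10000 nM and 150000 nM.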

Compound 4, concentration for 50% growth inhibition: 25000 nM
Compound 4: the middle estimate sits 1.6-fold (0.20 log units) above what was measured, within the range that was stated.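

In this assay, 4-fluorophenyl in place of 4-methylbenzyl on a sulfur gives a 2.0-fold lower number from compound 3 to compound 4 (0.30 log units; within the scatter). Set beside the step on the sulfonyl sulfur, the change carries over between the two cores with no difference that can be told from scatter: the same change on two cores in this assay, no change at the digits printed (within the scatter) from compound 1 to compound 2 and a 2.0-fold lower number (0.30 log units; within the scatter) from compound 3 to compound 4, 2.0-fold (0.30 log units) apart, within the scatter of two such steps This rests on only two pairs, each with a step inside the scatter, so it does not show that the change would stay as small on any further core, and it does not say what separates the two cores, which differ in more than one place.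

Still open is what the sulfonyl sulfur and the plain sulfur each contribute on an otherwise identical core, as no pair shown isolates that difference. Also open, as far as these compounds go, is how the series would read with an amine or a carboxylic acid on the aromatic ring carried by the sulfur, or with a longer chain on the sulfur in place of 4-methylbenzyl.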